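From bromo to nitro on the shared core

This account rests on a few compounds, and the source may have more. Where it says the series, first, only, none or still open, it means among the compounds named here.

In a functional assay on CCRF-CEM cells (Homo sapiens) for antiproliferative activity, read by cell counting, with a stated time of 2 days (a higher number here means a weaker inhibitor, a lower number a stronger inhibitor), compound 1 (`COc1ccc(Nc2nc(N)c(C(=O)c3ccccc3)s2)cc1`) gives 300 nM and compound 2 (`COc1ccc(Nc2nc(N)c(C(=O)c3ccc(Cl)cc3)s2)cc1`) gives 19 nM. Compound 3 (`COc1ccc(Nc2nc(N)c(C(=O)c3ccc(Br)cc3)s2)cc1`) gives 39 nM, the second highest of the three numbers. Compound 4 (`COc1ccc(Nc2nc(N)c(C(=O)c3ccc([N+](=O)[O-])cc3)s2)cc1`) differs from it by nitro in place of bromo on an aromatic carbon, with nitro in place of bromo, para to a large group. Chloro in place of hydrogen brought a 16-fold lower number from compound 1 to compound 2 (1.20 log units; beyond the scatter) and bromo in place of hydrogen brought a 7.7-fold lower number from compound 1 to compound 3 (0.89 log units; beyond the scatter), while bromo in place of chloro brought a 2.1-fold higher number from compound 2 to compound 3 (0.31 log units; beyond the scatter). Among the measured compounds shown here, no measured compound carries nitro, so these steps guide only loosely. A modest rise in this assay is expected, an estimated 2.1-fold higher number from compound 3 to compound 4 (0.31 log units; beyond the scatter), leaving part of the drop seen for compound 3 (a 7.7-fold lower number from compound 1 to compound 3 (0.89 log units; beyond the scatter)) in place. For compound 4 the estimated value is 80 nM, within a range of 20 nM to 320 nM.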

Compound 4, half-maximal inhibitory concentration: 31 nM
The estimate for compound 4 lay 2.6-fold (0.41 log units) above the measured number; measured number inside the range.
By their numbers in this assay, from the lowest: compounds 2, 4 and 3 (each within the scatter of the next, the first and the last beyond it); then compound 1.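

In this assay, nitro on this aromatic carbon, para to a large group, keeps the gain over hydrogen, with a 9.7-fold lower number from compound 1 to compound 4 (0.99 log units; beyond the scatter). Against the halogens it gives a 1.3-fold lower number from compound 3 to compound 4 (0.10 log units; within the scatter) and a 1.6-fold higher number from compound 2 to compound 4 (0.21 log units; within the scatter), so a group of three heavy atoms with hydrogen-bond acceptors is not told apart here from either single halogen atom. No evidence at hand bears on this result.

The compounds shown leave open whether an amine or a carboxylic acid at this place would also keep the gain over hydrogen.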